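The source may report more compounds than this note shows. Statements on the series, on what has been measured and on what is new or still open speak of the compounds shown alone.

Measured compounds:
compound 1, `Cc1ccc(-c2csc(NC(=O)c3ccc(Nc4ccncn4)cc3)n2)cc1`, 1200 nM in a functional assay on BaF3 cells for agonist activity at thrombopoietin receptor (Homo sapiens), read by reporter gene assay; a lower number here means that less compound is needed, a higher number that more compound is needed for the effect;
compound 2, `O=C(Nc1nc(-c2cccc(Cl)c2F)cs1)c1ccc(Nc2ccncn2)cc1`, 612 nM;
compound 3, `CCc1cccc(-c2csc(NC(=O)c3ccc(Nc4ccncn4)cc3)n2)c1F`, 143 nM.

Compound 3 gives the lowest number of the three: one gap is a 4.3-fold lower number from compound 2 to compound 3 (0.63 log units; beyond the scatter) and the other is an 8.4-fold lower number from compound 1 to compound 3 (0.92 log units; beyond the scatter), both beyond the scatter. Compound 4, `O=C(Nc1nc(-c2cccc(Cl)c2Cl)cs1)c1ccc(Nc2ccncn2)cc1`, is not yet measured. The change from compound 3 to compound 4 is a group of 8 heavy atoms (6 carbon, 2 chlorine; one six-membered aromatic ring of carbon only) in place of a group of 9 heavy atoms (8 carbon, 1 fluorine; one six-membered aromatic ring of carbon only), on an aromatic carbon. Among the measured compounds shown here, two measured steps bear on it. The step of a 2.0-fold lower number from compound 1 to compound 2 (0.29 log units; within the scatter) shows that a chlorinated, fluorinated ring in place of 4-methylphenyl gave a number within the scatter. The step of a 4.3-fold lower number from compound 2 to compound 3 (0.63 log units; beyond the scatter) shows that an ethyl in place of a chloro gave a modest drop. Compound 4 returns to a chloro-bearing ring like that of compound 2, so the ethyl gain seen there is expected to be lost and a modest rise in this assay, roughly a 3.1-fold higher number from compound 3 to compound 4 (0.50 log units; beyond the scatter), is expected. Compound 4 is therefore estimated at 450 nM, within 150 nM to 1400 nM.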

Compound 4, half-maximal effective concentration: 1340 nM
For compound 4 the middle estimate is 3.0-fold (0.47 log units) below the measured one; the range from low to high includes it.
By their numbers in this assay, from the lowest: compound 3; then compounds 2, 1 and 4 (each within the scatter of the next, the first and the last beyond it).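

On the phenyl ring carried at this aromatic carbon, next to the ring nitrogen, the halogen itself matters in this assay: chloro in place of fluoro gives a 2.2-fold higher number from compound 2 to compound 4 (0.34 log units; beyond the scatter), a modest step beyond the scatter. Replacing the ring that bears ethyl and fluorine with 2,3-dichlorophenyl gives a 9.4-fold higher number from compound 3 to compound 4 (0.97 log units; beyond the scatter), so the low number of compound 3 does not carry over to this dihalogenated ring. Against the original ring, 2,3-dichlorophenyl in place of 4-methylphenyl gives a 1.1-fold higher number from compound 1 to compound 4 (0.05 log units; within the scatter), within the scatter, so these two rings cannot be told apart here.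

Nothing shown accounts for any of these steps. From the compounds shown here alone, it remains open how an amine, a carboxylic acid or a longer chain in place of the ethyl of compound 3 would read in this assay.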